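Replacing the thiazolyl ethenyl arm with a methylsulfanylphenyl ring

The source may hold more compounds than are shown below. What is called first, only, known or untested is meant among the compounds shown, and "the series" means these compounds.

The measured compounds and their values in an assay on isolated protein with Bile acid receptor (Homo sapiens) as the target; on this read-out higher numbers stand for an effect only at larger amounts of compound and lower numbers for an effect already at smaller amounts:
Compound 1, `COC(=O)/C=C/c1cccc(N(Cc2ccc(/C=C/c3cccc(C(F)(F)F)c3)cc2)C(=O)C(C)C)c1`, gives 267 nM.
Compound 2, `COC(=O)/C=C/c1cccc(N(Cc2ccc(/C=C/c3scnc3C)cc2)C(=O)C2CCCCC2)c1`, gives 227 nM.
Compound 3, `COC/C=C/c1cccc(N(Cc2ccc(/C=C/C(=O)OC(C)(C)C)cc2)C(=O)C2CCCCC2)c1`, gives 243 nM.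

In this assay compound 2 has the lowest of the three numbers, but its distance to compound 3 and to compound 1 both lie within the scatter, so the three compounds cannot be told apart on these values. Compound 4, `COC(=O)/C=C/c1cccc(N(Cc2ccc(-c3ccc(SC)cc3)cc2)C(=O)C2CCCCC2)c1`, has not yet been measured. It differs from compound 2 in one place: 4-(methylsulfanyl)phenyl in place of 2-(4-methyl-1,3-thiazol-5-yl)ethenyl on an aromatic carbon. Within the data shown here, no step between measured compounds is known for this kind of change, so there is no anchor beyond the three values themselves, which sit close together despite quite different groups at the same end of the molecule. From compound 2 to compound 4 a step of a 1.3-fold higher number from compound 2 to compound 4 (0.12 log units; within the scatter) is expected, which is small and within the scatter. Compound 4 is therefore estimated at 300 nM in this assay, in a range from 120 nM to 800 nM.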

Compound 4, half-maximal effective concentration: 69 nM
Compound 4: the middle estimate sits 4.3-fold (0.64 log units) above what was measured; measured number below the stated range.
By their numbers in this assay, from the lowest: compound 4; then compounds 2, 3 and 1 (each within the scatter of the next).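

In this assay, among these compounds, the exchange of the 2-(4-methyl-1,3-thiazol-5-yl)ethenyl arm for 4-(methylsulfanyl)phenyl gives a 3.3-fold lower number from compound 2 to compound 4 (0.52 log units; beyond the scatter), the only step available here and one beyond the scatter. Among the compounds shown here, it shows that this place, on an aromatic carbon of a six-membered aromatic ring of carbon only and para to a large group, is sensitive to the group it carries, even with the same number of heavy atoms leaving and entering, which the earlier compounds, having no step among them, could not show. Nothing among the data accounts for the size of this step.

The change removes the double bond outside aromatic rings, swaps the ring and adds the methylsulfanyl group all at once, and the compounds shown do not separate these parts. As far as these compounds go, whether a plain phenyl, a 4-methoxyphenyl or a 4-(methylsulfonyl)phenyl at this place would give a similar number remains open.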